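The compounds below may be only part of what the source reports. "The series", "measured", "known", "first", "only" and "open" are said of these compounds alone.

Measured compounds:
compound 1 `COc1ccc(C2=NN(C3=NC(=O)/C(=C4\C(=O)Nc5ccc(Br)cc54)S3)C(c3ccc(OC)cc3)C2)cc1` gives 480 nM
compound 2 `COc1ccc(C2=NN(C3=NC(=O)/C(=C4\C(=O)Nc5ccc(Cl)cc54)S3)C(c3ccc(OC)cc3)C2)cc1` gives 500 nM
compound 3 `CN(C)c1ccc(C2CC(c3ccccc3)=NN2C2=NC(=O)/C(=C3\C(=O)Nc4ccc(Br)cc43)S2)cc1` gives 510 nM

All three were tested in a functional assay on cells (Cancer cell lines, Homo sapiens) for cytotoxicity, read by sulforhodamine B assay, with a stated time of 48 h; a higher number here means a weaker inhibitor of growth, a lower number a stronger inhibitor of growth. Compound 1 and compound 2 share one core and differ only by chloro in place of bromo on an aromatic carbon; that change made a step of a 1.0-fold higher number from compound 1 to compound 2 (0.02 log units; within the scatter). Compound 3 rests on a different core, and the difference between the two cores is not broken down here. Compound 4 `CN(C)c1ccc(C2CC(c3ccccc3)=NN2C2=NC(=O)/C(=C3\C(=O)Nc4ccc(Cl)cc43)S2)cc1` is the partner of compound 3, differing from it by chloro in place of bromo on an aromatic carbon; the surroundings of the place are described in the same words as before, so this is the same change. The value of compound 3 in this assay sits close to those of compound 1 and compound 2. The step from compound 3 to compound 4 is expected to be a 1.0-fold higher number from compound 3 to compound 4 (0.02 log units; within the scatter), essentially flat, because a 1.0-fold higher number from compound 1 to compound 2 (0.02 log units; within the scatter) stayed within the scatter. In this assay compound 4 is therefore estimated at 530 nM, most likely between 300 nM and 950 nM.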

Compound 4, concentration for total growth inhibition: 530 nM
The estimate for compound 4 equals the measured number at the digits printed, within the range that was stated.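

In this assay, chloro in place of bromo gave a 1.0-fold higher number from compound 3 to compound 4 (0.02 log units; within the scatter). Set beside the earlier case, the change carried from one core to the other with no difference that can be told apart: the same change on two cores in this assay, a 1.0-fold higher number (0.02 log units; within the scatter) from compound 1 to compound 2 and a 1.0-fold higher number (0.02 log units; within the scatter) from compound 3 to compound 4, 1.0-fold (0.00 log units) apart, within the scatter of two such steps. This shows that swapping these two groups left the number flat on both cores in this assay, but two cores in one assay do not show that the swap would stay flat on other cores, and a flat step cannot show how a change with a real effect would carry over.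

The compounds shown leave open what a group other than these two, such as a nitrile, an amine or a carboxylic acid, would do on the same aromatic carbon. They also leave open how either core would respond to such a group.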